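The source may report more compounds than this note shows. Statements on the series, on what has been measured and on what is new or still open speak of the compounds shown alone.

In a functional assay on A549 cells (Homo sapiens) for cytotoxicity, read by MTT assay, with a stated time of 48 h (a lower number here means a stronger inhibitor, a higher number a weaker inhibitor), compound 1 `CN1CCN(CCCCOc2c(O)cc(O)c3c(=O)cc(-c4ccccc4)oc23)CC1` gives > 100000 nM, which is a limit of the assay and not a number. In this assay compound 2 `CC(C)NCCOc1c(O)cc(O)c2c(=O)cc(-c3ccccc3)oc12` has the entry "not determined" (no result reported), so it holds no place on the scale and offers no starting value. Compound 3 `CN1CCN(CCCOc2c(O)cc(O)c3c(=O)cc(-c4ccccc4)oc23)CC1` has yet to be measured. The structural change is (4-methylpiperazin-1-yl)methyl in place of isopropylamino on a saturated chain carbon, two bonds along the chain from an oxygen on an aromatic ring. In words, (4-methylpiperazin-1-yl)methyl stands in place of isopropylamino on a saturated chain carbon, two bonds along the chain from an oxygen on an aromatic ring. Cut one bond further out, the same change reads 2-(isopropylamino)ethyl to 3-(4-methylpiperazin-1-yl)propyl. With no number for compound 2, the size of this step cannot be measured against a starting point, and no clear step in either direction is expected. Compound 3 is instead expected to be a weak inhibitor, sitting high on the scale of this assay. That expectation rests on compound 1 and (the limit of > 100000 nM in this assay, at which 1 of the 2 values shown sits). The estimate for compound 3 is 70000 nM, with an expected range from 20000 nM to 200000 nM.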

Compound 3, half-maximal inhibitory concentration: > 100000 nM
Compound 3 was reported as a limit (the forecaster's own chance of this, stated with the estimate: 50%); middle value at least 1.4-fold (0.15 log units) from the limit.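

Compound 1 and compound 3 each give a limit of the assay and not a number, and compound 2 holds no place on the scale, so no new step can be read among them: the limit of > 100000 nM in this assay, at which 2 of the 3 values shown sit.

Still open, going by these compounds, is how strong compound 1 and compound 3 really are in this assay, and whether (4-methylpiperazin-1-yl)methyl in place of isopropylamino changes the result at all.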